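The source may report more compounds than this note shows. Statements on the series, on what has been measured and on what is new or still open speak of the compounds shown alone.

Measured in a functional assay on Rec1 cells (Homo sapiens) for inhibition, read by luminescence and CellTiter-Glo, with a stated time of 72 h; on this read-out lower numbers stand for stronger inhibition and higher numbers for weaker inhibition:
compound 1 `CCOC(=O)c1cc(-c2ccc(Oc3ccccc3)cc2)nn1Cc1cccc(NC(=O)CCl)c1`: 400 nM
compound 2 `C/C=C/C(=O)Nc1ccc(Cn2nc(-c3ccc(Oc4ccccc4)cc3)cc2C(=O)OCC)cc1`: 13100 nM
compound 3 `C/C=C/C(=O)Nc1cccc(Cn2nc(-c3ccc(Oc4ccccc4)cc3)cc2C(=O)OCC)c1`: 7800 nM

Compound 1 stands lowest of the three. The nearest gap is a 20-fold higher number from compound 1 to compound 3 (1.29 log units; beyond the scatter), and the furthest is a 33-fold higher number from compound 1 to compound 2 (1.52 log units; beyond the scatter). The remaining pair shows a 1.7-fold lower number from compound 2 to compound 3 (0.23 log units; within the scatter).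

Compound 4 `O=C(CCl)Nc1cccc(Cn2nc(-c3ccc(Oc4ccccc4)cc3)cc2CO)c1` keeps the 3-(((chloromethyl)carbonyl)amino)phenyl of compound 1 and changes another place: hydroxymethyl in place of ethoxycarbonyl on an aromatic carbon. Within the data shown here, no measured step touches that place, since all three concern the amide-bearing phenyl, so none of them transfers directly. A rise in this assay is expected, though with little support, and it is expected to be smaller than a 20-fold higher number from compound 1 to compound 3 (1.29 log units; beyond the scatter). The expected change is a 2.0-fold higher number from compound 1 to compound 4 (0.30 log units; within the scatter). Compound 4 is estimated at 800 nM, within a range of 200 nM to 4000 nM.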

Compound 4, half-maximal inhibitory concentration: 400 nM
Estimate against measurement, compound 4: 2.0-fold (0.30 log units) above, within the range that was stated.
By their numbers in this assay, from the lowest: compounds 1 and 4 (each within the scatter of the next); then compounds 3 and 2 (each within the scatter of the next).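

In this assay the step at this aromatic carbon reads no change at the digits printed from compound 1 to compound 4 (within the scatter) and so shows that ethoxycarbonyl, with 5 heavy atoms and no hydrogen-bond donor, can give way to hydroxymethyl, with 2 heavy atoms and 1 donor, without a change beyond the scatter. Among these compounds, the earlier steps all concerned the amide-bearing phenyl, so this is the first reading at this position. Nothing available explains the result.

As far as these compounds go, whether a carboxylic acid, an aminomethyl group or a longer ester at this carbon would read the same remains open. So does whether hydroxymethyl would behave alike alongside the prop-1-en-1-yl amide of compound 3.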